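The compounds below may be only part of what the source reports. "The series", "measured", "known", "first", "only" and "open" are said of these compounds alone.

Working notes on the series. The set so far holds compound 1 `CS(=O)(=O)N1CCN(CC(O)CN2CCC(CNC(=O)c3cccc4[nH]c(C5CC5)nc34)CC2)CC1` and compound 2 `CC(C)c1nc2c(C(=O)NCC3CCN(CCN4CCN(S(C)(=O)=O)CC4)CC3)cccc2[nH]1`, both carrying the shared core with a substituted piperazine. In an assay on isolated protein for binding affinity to 5-hydroxytryptamine receptor 3A (Homo sapiens) (a lower number here means a stronger inhibitor, a higher number a weaker inhibitor), compound 1 gives 50100 nM, and compound 2 gives 100000 nM in this assay; the two numbers lie within the scatter of each other, so no order can be read between them. Compound 3 `COC(=O)N1CCN(CCN2CCC(CNC(=O)c3cccc4[nH]c(C(C)C)nc34)CC2)CC1` differs from compound 2 only by methoxycarbonyl in place of methylsulfonyl on an amine nitrogen in a ring. Within the data shown here, no step between measured compounds is available to calibrate this change; with both measured values this weak, the expected step of a 1.3-fold lower number from compound 2 to compound 3 (0.10 log units; within the scatter) is none beyond the scatter. Compound 3 is therefore expected to give about 80000 nM, in a range from 20000 nM to 300000 nM.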

Compound 3, inhibition constant: 79400 nM
Beside the measured number, compound 3's estimate is 1.0-fold (0.00 log units) above it; low and high end bracket the measured number.
By their numbers in this assay, from the lowest: compounds 1, 3 and 2 (each within the scatter of the next).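

Methoxycarbonyl in place of methylsulfonyl on an amine nitrogen in a ring gives a 1.3-fold lower number from compound 2 to compound 3 (0.10 log units; within the scatter) in this assay and this is the first one-place comparison in the set. The two groups cannot be told apart at this position, and both compounds remain weak, so the step shows no sensitivity to this change. Nothing on hand offers an explanation for this result.

On these data alone, whether a longer chain, an amine or a carboxylic acid at this nitrogen would give a number beyond the scatter stays open.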